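Sec-butyl ester to propargyl ether on the shared core

The compounds below may be only part of what the source reports. "The series", "measured", "known", "first", "only" and "open" are said of these compounds alone.

- compound 1 `CCCOC(=O)c1cc(N2C(=O)C3=C(CCCC3)C2=O)c(F)cc1Cl`: 89.1 nM
- compound 2 `CCC(C)OC(=O)c1cc(N2C(=O)C3=C(CCCC3)C2=O)c(F)cc1Cl`: 24.6 nM

In a functional assay on the whole organism with Scenedesmus acutus as the target (on this read-out higher numbers stand for weaker inhibition and lower numbers for stronger inhibition), compound 2 has the lower of the two numbers, at 24.6 nM. Among the compounds with values here, the only measured step is a 3.6-fold lower number from compound 1 to compound 2 (0.56 log units; beyond the scatter), which lies beyond the scatter and is modest. It comes from adding a methyl on the ester chain.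

The next compound is compound 3 `C#CCOc1cc(N2C(=O)C3=C(CCCC3)C2=O)c(F)cc1Cl`, which has not yet been measured. The change is propargyloxy in place of sec-butoxycarbonyl on an aromatic carbon, ortho to a chloro group and para to a fluoro group. This replaces the whole sec-butoxycarbonyl group, whereas the measured step only altered its chain. The step of a 3.6-fold lower number from compound 1 to compound 2 (0.56 log units; beyond the scatter) therefore bears on it only loosely, as a guide to how far a change at this place can move the number in this assay. The data give no direction for this replacement, so no clear shift beyond the scatter is expected, though a wide range is warranted. The expected step is a 1.2-fold lower number from compound 2 to compound 3 (0.09 log units; within the scatter). For compound 3 the estimated value is 20 nM, with an expected range from 5 nM to 80 nM.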

Compound 3, half-maximal inhibitory concentration: 15.9 nM
Compound 3: middle estimate off by 1.3-fold (0.10 log units), on the high side; low and high end bracket the measured number.
By their numbers in this assay, from the lowest: compounds 3 and 2 (each within the scatter of the next); then compound 1.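

In this assay, exchanging the whole sec-butoxycarbonyl group for propargyloxy on this aromatic carbon gives a 1.5-fold lower number from compound 2 to compound 3 (0.19 log units; within the scatter), so the step stays within the scatter even though the carbonyl is gone and the entering group has fewer heavy atoms. Measured against the unbranched ester, the same kind of replacement gives a 5.6-fold lower number from compound 1 to compound 3 (0.75 log units; beyond the scatter), so this position accepts an ether-linked group as well as an ester and is not limited to changes in the ester chain. Nothing at hand accounts for either step.

Still open, from the compounds shown here alone, is how a propoxy or allyloxy group on the same aromatic carbon would compare with propargyloxy, a comparison that would separate the contribution of the triple bond from that of the ether oxygen. Also open, going by these compounds, is how the read-out responds to a longer chain on that oxygen, or to a carboxylic acid or an amine at this place, so the range of groups tolerated here remains undefined.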